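Glucagon receptor binding: trifluoromethoxy to trifluoromethyl on the aryl

The source may hold more compounds than are shown below. What is called first, only, known or untested is meant among the compounds shown, and "the series" means these compounds.

Measured so far:
compound 1 `O=C(O)CCNC(=O)c1ccc(CN(c2ccc(Cl)cc2)c2nc(-c3ccc(OC(F)(F)F)cc3)cs2)cc1`: 82 nM
compound 2 `O=C(O)CCNC(=O)c1ccc(CN(c2ccc3c(c2)CCC3)c2nc(-c3ccc(C(F)(F)F)cc3)cs2)cc1`: 86 nM

In an in vitro assay on BHK cells for displacement of a labelled ligand from Glucagon receptor (Homo sapiens), read by scintillation proximity assay (a higher number here means a weaker inhibitor, a lower number a stronger inhibitor), compound 1 gives 82 nM and compound 2 gives 86 nM. The two numbers lie within the scatter of each other, so compound 1 stands level with compound 2 and neither can be placed ahead of the other.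

Compound 3 `O=C(O)CCNC(=O)c1ccc(CN(c2ccc(Cl)cc2)c2nc(-c3ccc(C(F)(F)F)cc3)cs2)cc1` is not yet measured. It differs from compound 1 by trifluoromethyl in place of trifluoromethoxy on an aromatic carbon. Within the data shown here, no measured pair isolates this change, so its size is not known from the series. The expected step in this assay is a 1.1-fold higher number from compound 1 to compound 3 (0.04 log units; within the scatter), a step not beyond the scatter, in no clear direction. Compound 3 is estimated at 90 nM, within 40 nM to 200 nM.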

Compound 3, half-maximal inhibitory concentration: 76 nM
Estimate against measurement, compound 3: 1.2-fold (0.07 log units) above; the measured number falls inside the stated range.
By their numbers in this assay, from the lowest: compounds 3, 1 and 2 (each within the scatter of the next).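

In this assay the exchange of trifluoromethoxy for trifluoromethyl gives a 1.1-fold lower number from compound 1 to compound 3 (0.03 log units; within the scatter) with the 4-chlorophenyl group held fixed, so at this position the two groups cannot be told apart. With trifluoromethyl held fixed, 4-chlorophenyl in place of 2,3-dihydro-1H-inden-5-yl gives a 1.1-fold lower number from compound 2 to compound 3 (0.05 log units; within the scatter) and the two nitrogen substituents likewise stand level. Nothing on hand explains either result.

From the compounds shown here alone, whether this level binding would hold with a nitrile or an amine at the same position stays open. So does the effect of a bare hydrogen there.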